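The source may report more compounds than this note shows. Statements on the series, on what has been measured and on what is new or still open speak of the compounds shown alone.

Measured compounds in a functional assay on MCF7 cells (Homo sapiens) for antiproliferative activity, read by sulforhodamine B assay, with a stated time of 48 h; a lower number here means a stronger inhibitor, a higher number a weaker inhibitor:
compound 1, `COc1ccc(/C=C/C(=O)C(=Cc2cc(Br)c(O)c(OC)c2)C(=O)/C=C/c2ccc(OC)cc2OC)c(OC)c1`: compound 1 gives 2600 nM;
compound 2, `COc1ccc(/C=C/C(=O)C(=Cc2cc(OC)c(O)c(OC)c2)C(=O)/C=C/c2ccc(OC)cc2OC)c(OC)c1`: compound 2 gives 970 nM;
compound 3, `COc1cc(OC)c(/C=C/C(=O)C(=Cc2cc(Br)c(O)c(OC)c2)C(=O)/C=C/c2c(OC)cc(OC)cc2OC)c(OC)c1`: compound 3 gives 1460 nM.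

Compound 1 and compound 2 differ in one place: methoxy in place of bromo on an aromatic carbon. In this assay this change gives a 2.7-fold lower number from compound 1 to compound 2 (0.43 log units; beyond the scatter), a modest step that lies beyond the usual scatter. The unmeasured compound 4, `COc1cc(OC)c(/C=C/C(=O)C(=Cc2cc(OC)c(O)c(OC)c2)C(=O)/C=C/c2c(OC)cc(OC)cc2OC)c(OC)c1`, is related to compound 3 by the same change: methoxy in place of bromo on an aromatic carbon. The surroundings of the changed position are described in the same words for both pairs, so the change is the same one. How the core of compound 3 differs from the core of compound 1 is not broken down here; the two values lie within the scatter of each other, as do those of compound 3 and compound 2. Compound 4 is expected to make a step of a 2.4-fold lower number from compound 3 to compound 4 (0.39 log units; beyond the scatter), resting on the single earlier occurrence because of a 2.7-fold lower number from compound 1 to compound 2 (0.43 log units; beyond the scatter). Compound 4 is estimated at 600 nM, with a range from 250 nM to 1400 nM.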

Compound 4, half-maximal inhibitory concentration: 1030 nM
Estimate against measurement, compound 4: 1.7-fold (0.23 log units) below; the range from low to high includes it.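

In this assay, methoxy in place of bromo, which turns the 3-bromo-4-hydroxy-5-methoxyphenyl group into the 4-hydroxy-3,5-dimethoxyphenyl group, gives a 1.4-fold lower number from compound 3 to compound 4 (0.15 log units; within the scatter). Set beside the earlier occurrence of this change, the new step does not stand apart from it: the same change on two cores in this assay, a 2.7-fold lower number (0.43 log units; beyond the scatter) from compound 1 to compound 2 and a 1.4-fold lower number (0.15 log units; within the scatter) from compound 3 to compound 4, 1.9-fold (0.28 log units) apart, within the scatter of two such steps. Within the data shown here, this shows that the two cores cannot be told apart on this change, but it does not show that the change has the same size on both, as only two pairs are available and only the step on the core of compound 1 lies beyond the scatter.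

The compounds shown carry only bromo or methoxy at this place, so it remains open how an amine, a carboxylic acid or a longer chain such as propoxy would behave there. All four also keep the hydroxy group, which leaves open whether the change would read the same with a fluoro group or an amine at that position, or on any other core.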